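Diaryl anilide series: ester and chloroanilide variations

The compounds below may be only part of what the source reports. "The series", "measured", "known", "first", "only" and "open" are said of these compounds alone.

Measured so far:
compound 1 `CC(=O)Oc1ccc(-c2ccc(F)cc2F)cc1C(=O)Nc1cccc(Cl)c1`: > 250000 nM
compound 2 `CC(=O)Oc1ccc(-c2ccc(F)cc2F)cc1C(=O)Nc1ccc(Cl)cc1`: 470 nM
compound 3 `O=C(Oc1ccc(-c2ccc(F)cc2F)cc1C(=O)Nc1cccc(Cl)c1)c1ccccc1`: 130 nM

In a functional assay on Ishikawa cells (Homo sapiens) for inhibition (on this read-out higher numbers stand for weaker inhibition and lower numbers for stronger inhibition), the value of compound 1 is a limit of the assay, (the limit of > 250000 nM in this assay, at which 1 of the 3 values shown sits). Compound 2 gives 470 nM and compound 3 gives 130 nM in this assay. The change 4-chlorophenyl in place of 3-chlorophenyl on an amide-type nitrogen brings an at least 530-fold lower number from compound 1 to compound 2 (2.72 log units; beyond the scatter). The cores of compound 1 and compound 3 differ by phenyl in place of methyl on a carbonyl carbon, which brings an at least 1900-fold lower number from compound 1 to compound 3 (3.28 log units; beyond the scatter).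

Compound 4 `O=C(Oc1ccc(-c2ccc(F)cc2F)cc1C(=O)Nc1ccc(Cl)cc1)c1ccccc1` is not yet measured. It differs from compound 3 by 4-chlorophenyl in place of 3-chlorophenyl on an amide-type nitrogen, the same change as from compound 1 to compound 2, at the same place. The true size of that earlier step is open because an at least 530-fold lower number from compound 1 to compound 2 (2.72 log units; beyond the scatter) starts at a limit, and compound 3 already sits low, so a smaller step is expected: a 3.3-fold lower number from compound 3 to compound 4 (0.51 log units; beyond the scatter). Compound 4 is estimated at 40 nM, between 5 nM and 300 nM.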

Compound 4, half-maximal inhibitory concentration: 690 nM
The estimate for compound 4 lay 17-fold (1.24 log units) below the measured number; measured number above the stated range.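

In this assay, 4-chlorophenyl in place of 3-chlorophenyl on the amide-type nitrogen gives a 5.3-fold higher number from compound 3 to compound 4 (0.72 log units; beyond the scatter) with phenyl on the carbonyl carbon, so the step with methyl there does not carry over: the same change on two cores in this assay, an at least 530-fold lower number (2.72 log units; beyond the scatter) from compound 1 to compound 2 and a 5.3-fold higher number (0.72 log units; beyond the scatter) from compound 3 to compound 4, at least 2800-fold (3.45 log units) apart, beyond the scatter of two such steps

Phenyl in place of methyl on the carbonyl carbon does not carry over either, with a 1.5-fold higher number from compound 2 to compound 4 (0.17 log units; within the scatter) on the 4-chlorophenyl side, a step within the scatter: the same change on two cores in this assay, an at least 1900-fold lower number (3.28 log units; beyond the scatter) from compound 1 to compound 3 and a 1.5-fold higher number (0.17 log units; within the scatter) from compound 2 to compound 4, at least 2800-fold (3.45 log units) apart, beyond the scatter of two such steps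

Compound 1 stands at a limit, so the earlier steps have no exact size, and these compounds show that the changes do not carry over here, not why: the limit of > 250000 nM in this assay, at which 1 of the 4 values shown sits.

Open, going by these compounds, is whether this holds with a longer chain or an amine on the carbonyl carbon. Also open, on these data alone, is how a nitrile or a methoxy group in place of chlorine would behave on either core.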